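This account rests on a few compounds, and the source may have more. Where it says the series, first, only, none or still open, it means among the compounds named here.

Within the data shown here, compound 1 `Cc1nn(Cc2ccccc2)c(C)c1NC(=O)c1ccc(COc2ccccc2)cc1` is the one compound here that gives an actual number in a functional assay on MIA PaCa-2 cells (Homo sapiens) for antiproliferative activity, read by MTT assay, with a stated time of 72 h; a lower number here means that less compound is needed, a higher number that more compound is needed for the effect: compound 1 gives 10000 nM. Compound 2 `Cc1nn(Cc2ccc(C(N)=O)cc2)c(C)c1NC(=O)c1ccc(COc2ccccc2)cc1` carries a carbamoyl group on the benzyl ring, and in this assay compound 2 gives only > 100000 nM, which is a limit of the assay and not a number. That limit is the limit of > 100000 nM in this assay, at which 1 of the 2 values shown sits. The step of an at least 10-fold higher number from compound 1 to compound 2 (1.00 log units; beyond the scatter) therefore shows that adding carbamoyl to this ring costs activity, though how much beyond the limit is not known.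

Compound 3 `Cc1nn(Cc2cccc(C(N)=O)c2)c(C)c1NC(=O)c1ccc(COc2ccccc2)cc1` has not yet been measured. It differs from compound 1 by carbamoyl in place of hydrogen on an aromatic carbon, the carbamoyl sitting meta to a large group on the same benzyl ring. Among the measured compounds shown here, the only measured step that bears on it is the one from compound 1 to compound 2, so a weakening of similar kind is expected, with a 5.0-fold higher number from compound 1 to compound 3 (0.70 log units; beyond the scatter). Compound 3 is accordingly estimated at 50000 nM, within 10000 nM to 150000 nM.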

Compound 3, half-maximal effective concentration: 9200 nM
The estimate for compound 3 lay 5.4-fold (0.74 log units) above the measured number, and the stated range ends above it.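

In this assay, a carbamoyl group on the benzyl ring does not by itself cost activity, since the step for adding it as 3-carbamoylphenyl is a 1.1-fold lower number from compound 1 to compound 3 (0.04 log units; within the scatter). What separates the two carbamoyl compounds is where the group sits on the ring, with 3-carbamoylphenyl and 4-carbamoylphenyl giving an at least 10-fold lower number from compound 2 to compound 3 (1.03 log units; beyond the scatter). The true size of that second step is unknown, as compound 2 has a limit of the assay and not a number: the limit of > 100000 nM in this assay, at which 1 of the 3 values shown sits.

The compounds shown leave open whether a carboxylic acid or a nitrile in place of the carbamoyl group would match compound 3 or fall away like compound 2. They also do not tell why the place of the group matters, or whether any group on this ring could give a clearly lower number than compound 1.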